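Removing the bromo from compound 3

The source may hold more compounds than are shown below. What is called first, only, known or untested is meant among the compounds shown, and "the series" means these compounds.

Of the compounds shown here, three of one series have been measured in a functional assay for inhibition, with a stated time of 5 min, tested at 1 mM; on this read-out lower numbers stand for less inhibition and higher numbers for more inhibition at the one concentration tested (going by the name of the read-out). Compound 1 `COc1ccc(/C(Cl)=C/C=C(\C#N)C(=O)c2c[nH]c3ccccc23)cc1` gives 61.3%, compound 2 `Cc1[nH]c2ccccc2c1C(=O)/C(C#N)=C/C=C(\Cl)c1ccc(Br)cc1` gives 69.1%, and compound 3 `N#C/C(=C\C=C(/Cl)c1ccc(Br)cc1)C(=O)c1c[nH]c2ccc(Br)cc12` gives 83.6%. Compound 3 stands highest of the three; compound 2 lies nearest, below it by a gap beyond the usual scatter, and compound 1 lies further below, also beyond the scatter. Compound 4 `N#C/C(=C\C=C(/Cl)c1ccc(Br)cc1)C(=O)c1c[nH]c2ccccc12` differs from compound 3 in one place: hydrogen in place of bromo on an aromatic carbon. For the measured compounds named here, no measured pair separated by a single change is available, so the size of this step is unknown. Because compound 1 gives 61.3% and compound 2 gives 69.1%, both below compound 3, a modest downward step is expected. The expected step from compound 3 to compound 4 is a number 15.6 percentage points lower from compound 3 to compound 4 (beyond the scatter). Compound 4 is estimated to reach 68%, within a range from 54% to 82%.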

Compound 4, a percentage reported as inhibition, at one concentration (the size of the read-out at that concentration, not a potency): 65.5%
For compound 4 the middle estimate is 2.5 percentage points above the measured one; the range from low to high includes it.
By their numbers in this assay, from the lowest: compounds 1, 4 and 2 (each within the scatter of the next); then compound 3.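

In (this assay), bromo on this aromatic carbon of the shared core makes a difference beyond the scatter, as hydrogen in its place gives (a number 18.1 percentage points lower from compound 3 to compound 4 (beyond the scatter)). Neither hydrogen in place of methyl (a number 3.6 percentage points lower from compound 2 to compound 4 (within the scatter)) nor bromo in place of methoxy (a number 4.2 percentage points higher from compound 1 to compound 4 (within the scatter)) moves the number beyond the scatter, so among these single changes only the loss of this bromo does. No measurement on hand gives a cause for these steps. From the compounds shown here alone, whether chloro, an amine or a carboxylic acid on this carbon would match bromo remains open.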